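The source may report more compounds than this note shows. Statements on the series, on what has been measured and on what is new or still open speak of the compounds shown alone.

Compound 1 `COc1ccc(OC)c(Nc2cc(Nc3ccc(F)cc3)ncn2)c1` was tested in an assay for inhibition of Receptor tyrosine-protein kinase erbB-3 variant L858R (Homo sapiens), read by mobility shift assay, with a stated time of 10 min (on this read-out higher numbers stand for weaker inhibition and lower numbers for stronger inhibition), where compound 1 gives 230 nM. Of the two numbers shown it stands lowest; its nearest neighbour is compound 2 `COc1ccc(OC)c(Nc2cc(Nc3ccc(S(N)(=O)=O)cc3)ncn2)c1`, which in this assay gives 619 nM. The step of a 2.7-fold higher number from compound 1 to compound 2 (0.43 log units; beyond the scatter) is modest. A third compound, compound 3 `COc1cc(Nc2cc(Nc3ccc(Cl)cc3)ncn2)cc(OC)c1OC`, was also run in this assay; compound 3 returns only a limit, > 10000 nM, which is the limit of > 10000 nM in this assay, at which 1 of the 3 values shown sits.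

Compound 4 `COc1ccc(OC)c(Nc2cc(NC(=O)CCCC(=O)O)ncn2)c1` has not yet been measured in this assay. It differs from compound 1 as follows: (3-carboxypropyl)carbonyl in place of 4-fluorophenyl on a nitrogen on an aromatic ring. Going by the values given here, none of the measured steps bears directly on this change. The only step shown, a 2.7-fold higher number from compound 1 to compound 2 (0.43 log units; beyond the scatter), exchanges one group upon the 4-fluorophenyl for another while the ring itself stays; in compound 4 the whole 4-fluorophenyl leaves and an open chain with a carboxylic acid takes its place. Among the compounds with values here, with no close precedent, the author expects the number for compound 4 to move upward, and by more than the scatter, with a real chance that only a limit is returned; the expected step is a 13-fold higher number from compound 1 to compound 4 (1.12 log units; beyond the scatter). The estimate for compound 4 in this assay is 3000 nM, with a range from 500 nM to 20000 nM.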

Compound 4, half-maximal inhibitory concentration: > 10000 nM
Compound 4 gave a limit, no number; the forecaster's own chance of this, stated with the estimate: 30%; middle value at least 3.3-fold (0.52 log units) from the limit.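

At the nitrogen on an aromatic ring, the earlier step changed only a group on the 4-fluorophenyl while the ring stayed, and it was modest: a 2.7-fold higher number from compound 1 to compound 2 (0.43 log units; beyond the scatter). On these data alone, replacing the whole 4-fluorophenyl with the open (3-carboxypropyl)carbonyl chain is a large step in this assay, an at least 43-fold higher number from compound 1 to compound 4 (1.63 log units; beyond the scatter), and since compound 4 returns a limit and not a number, the true size of this step stays unknown. The result shows that inhibition on this read-out does not survive this exchange, and it places a second compound at the end of the measurable range: the limit of > 10000 nM in this assay, at which 2 of the 4 values shown sit.

This one change removes the aromatic ring and brings in a carbonyl and a carboxylic acid together, so the compounds shown leave open which of these parts accounts for the loss. A plain butanoyl chain without the acid, the methyl ester of the acid, or a phenyl ring bearing a carboxylic acid on that nitrogen would each separate these parts, and only a value below the limit would give a step that can be sized.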